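A few compounds are considered here, and "the series" means these few. Any claim that something is new, unique, unknown or untested is made for them only; others in the source may bear on it.

Compound 2 `Cc1cc(C(=O)O)ccc1-c1noc(-c2ccc(C3CCCCC3)cc2)n1` is tested in a functional assay on CHO cells with sphingosine 1-phosphate receptor 4 (Homo sapiens) as the target, read by GTPgammaS binding; a lower number here means that less compound is needed, a higher number that more compound is needed for the effect. In this assay compound 2 gives > 10000 nM, which is a limit of the assay rather than a number. Compound 1 `Cc1ccccc1-c1noc(-c2ccc(C3CCCCC3)cc2)n1` likewise reaches only a limit in this assay, giving > 10000 nM. The step that the two limits leave unreadable from compound 1 to compound 2 has no readable size because of the limit of > 10000 nM in this assay, at which 2 of the 2 values shown sit. Compound 3 `Cc1cc(CC(=O)O)ccc1-c1noc(-c2ccc(C3CCCCC3)cc2)n1` differs from compound 2 by carboxymethyl in place of carboxy on an aromatic carbon. Among the measured compounds shown here, no measured step shows a readable size, so nothing here sets a direction for this change. Compound 3 is expected to give 10000 nM, between 2500 nM and 40000 nM. The resulting expected step is a number no higher from compound 2 to compound 3 (the limit leaves the size open).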

Compound 3, half-maximal effective concentration: > 10000 nM
Compound 3 was reported as a limit (the forecaster's own chance of this, stated with the estimate: 75%); the middle value lies on the limit itself.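

The steps among compound 1, compound 2 and compound 3 cannot be read because all three stop at a limit: the limit of > 10000 nM in this assay, at which 3 of the 3 values shown sit.

Going by these compounds, whether carboxy or carboxymethyl shifts the concentration needed in this assay at all, and by how much, stays open.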